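The source may report more compounds than this note shows. Statements on the series, on what has been measured and on what is new or still open speak of the compounds shown alone.

Measured compounds:
Compound 1 `CC1(C)c2[nH]nc(NC(=O)c3ccccc3)c2CN1Cc1cc(F)cc(F)c1`: 190 nM
Compound 2 `CN(C)c1ccc(C(=O)Nc2n[nH]c3c2CN(Cc2cc(F)cc(F)c2)C3(C)C)cc1`: 96 nM

Going by the values given here, in an assay on Sf21 cells for inhibition of high affinity nerve growth factor receptor (Homo sapiens), read by HTRF, with a stated time of 30 min, in the presence of a further agent that is not named here (a higher number here means a weaker inhibitor, a lower number a stronger inhibitor), compound 2 gives the lower of the two numbers, with compound 1 as its only neighbour; the step of a 2.0-fold lower number from compound 1 to compound 2 (0.30 log units; within the scatter) is within the scatter, so the two compounds cannot be told apart on these data.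

Compound 3 `CN1CCN(c2ccc(C(=O)Nc3n[nH]c4c3CN(Cc3cc(F)cc(F)c3)C4(C)C)cc2)CC1` differs from compound 2 in one place: 4-methylpiperazin-1-yl in place of dimethylamino on an aromatic carbon. Among the compounds with values here, only one measured step touches the same aromatic carbon, the change from hydrogen to dimethylamino in a 2.0-fold lower number from compound 1 to compound 2 (0.30 log units; within the scatter), and that step stayed within the scatter. Within the data shown here, there is no measured pair in which a dimethylamino group is exchanged for a larger ring-containing amine, so the present change cannot be read directly from any step. Given that the one related step was small, a step of the size a 1.0-fold higher number from compound 2 to compound 3 (0.02 log units; within the scatter) is expected, that is, no shift beyond the scatter in either direction. Compound 3 is therefore estimated at 100 nM, with a range from 40 nM to 250 nM.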

Compound 3, half-maximal inhibitory concentration: 17 nM
Compound 3: middle estimate off by 5.9-fold (0.77 log units), on the high side; the whole stated range lies above it.
By their numbers in this assay, from the lowest: compound 3; then compounds 2 and 1 (each within the scatter of the next).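

In this assay, the aromatic carbon para to a large group had so far shown only a step within the scatter, so it was unclear whether the group placed there mattered at all. Going by these compounds alone, the exchange of dimethylamino for 4-methylpiperazin-1-yl now gives a 5.6-fold lower number from compound 2 to compound 3 (0.75 log units; beyond the scatter), the first step at this carbon to lie beyond the scatter, and it shows that the number does depend on which amine sits there. Set against plain hydrogen, the same group gives an 11-fold lower number from compound 1 to compound 3 (1.05 log units; beyond the scatter), which makes compound 3 the strongest inhibitor of the three, and nothing available here accounts for this difference between the two amines.

The compounds shown leave open whether the step belongs to the six-membered ring as such or to its second nitrogen and the methyl group on it, a question that piperidin-1-yl, morpholin-4-yl or an unmethylated piperazin-1-yl at this carbon could separate. They also leave open whether an open-chain amine on a longer carbon chain, or a carboxylic acid, would be tolerated at the same carbon.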